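Sulfur for oxygen in the fused bicyclic base

This account rests on a few compounds, and the source may have more. Where it says the series, first, only, none or still open, it means among the compounds named here.

Three measured members share a triphosphate-bearing sugar and differ only in the fused bicyclic base. In a functional assay for agonist activity at P2Y purinoceptor 2 (Homo sapiens), read by FLIPR (a lower number here means that less compound is needed, a higher number that more compound is needed for the effect), compound 1 `O=c1c2cccnc2ccn1[C@@H]1O[C@H](COP(=O)(O)OP(=O)(O)OP(=O)(O)O)[C@@H](O)[C@H]1O` gives 35 nM, compound 2 `O=c1c2c(ccn1[C@@H]1O[C@H](COP(=O)(O)OP(=O)(O)OP(=O)(O)O)[C@@H](O)[C@H]1O)CCCC2` gives 55 nM, and compound 3 `O=c1c2ccoc2ccn1[C@@H]1O[C@H](COP(=O)(O)OP(=O)(O)OP(=O)(O)O)[C@@H](O)[C@H]1O` gives 68 nM. Compound 3 sits at the upper end of the three numbers, but its gaps to compound 2 and to compound 1 both fall within the usual scatter, so the three are not separated here.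

Compound 4 `O=c1c2ccsc2ccn1[C@@H]1O[C@H](COP(=O)(O)OP(=O)(O)OP(=O)(O)O)[C@@H](O)[C@H]1O` is not yet measured. It differs from compound 3 by a group of 10 heavy atoms (7 carbon, 1 nitrogen, 1 oxygen, 1 sulfur; one five-membered aromatic ring with 1 hetero atom, one six-membered aromatic ring with 1 hetero atom) in place of a group of 10 heavy atoms (7 carbon, 1 nitrogen, 2 oxygen; one five-membered aromatic ring with 1 hetero atom, one six-membered aromatic ring with 1 hetero atom), on a saturated ring carbon, that is, sulfur in place of one oxygen in the five-membered aromatic ring. Because compound 3 gives 68 nM and no comparison of this kind exists among the measured members, the step from compound 3 to compound 4 is expected to be a 1.2-fold lower number from compound 3 to compound 4 (0.09 log units; within the scatter), within the scatter in either direction. Compound 4 is therefore estimated at 55 nM, with a range from 20 nM to 150 nM.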

Compound 4, half-maximal effective concentration: 30 nM
Estimate against measurement, compound 4: 1.8-fold (0.26 log units) above, and the stated range covers the measured number.
By their numbers in this assay, from the lowest: compounds 4, 1, 2 and 3 (each within the scatter of the next, the first and the last beyond it).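

Sulfur in place of one oxygen in the five-membered aromatic ring is the only single-place comparison in the series, and in this assay it gives a 2.3-fold lower number from compound 3 to compound 4 (0.36 log units; beyond the scatter) as a modest step beyond the scatter. The fused bicyclic base therefore responds to this exchange even with the rest of the molecule unchanged. Nothing at hand accounts for the step.

From the compounds shown here alone, whether a nitrogen at the same ring position would hold this level remains open. So does the effect of a methyl group or a chlorine on the sulfur-containing ring.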